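Methoxy to Trifluoromethyl in a Weakly Cytotoxic Pair

This account rests on a few compounds, and the source may have more. Where it says the series, first, only, none or still open, it means among the compounds named here.

Compound 1 `COC(=O)c1ccc(-c2cccc(NC(=O)C(Cl)Cl)c2)cc1`: > 50000 nM, a limit of the assay
Compound 2 `COc1ccc(-c2cccc(NC(=O)C(Cl)Cl)c2)cc1`: 43300 nM

Among the measured compounds shown here, only two compounds have been measured in a functional assay on NCI-H460 cells (Homo sapiens) for cytotoxicity, read by MTT assay, with a stated time of 68 h; a lower number here means a stronger inhibitor, a higher number a weaker inhibitor. Compound 1 is reported there as a limit and not as a number, > 50000 nM, which is the assay ceiling (the limit of > 50000 nM in this assay, at which 1 of the 2 values shown sits). For the measured compounds named here, compound 2 gives 43300 nM and so holds the only numeric value in the set. The remaining value, that of compound 1, is a limit. Going by the values given here, the single measured step, an at least 1.1-fold lower number from compound 1 to compound 2 (0.06 log units; that floor lies within the scatter), is thus only a floor and carries no measurable size.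

Compound 3 `O=C(Nc1cccc(-c2ccc(C(F)(F)F)cc2)c1)C(Cl)Cl` differs from compound 2 by trifluoromethyl in place of methoxy on an aromatic carbon. Among the compounds with values here, the one measured step bears on this change only loosely: it exchanges a different pair of groups at the same kind of position and ends at a limit, so it shows no size at all. With nothing else to lean on, no step beyond the scatter is expected for a 1.1-fold lower number from compound 2 to compound 3 (0.03 log units; within the scatter). Compound 3 is therefore estimated at about 40000 nM, with a likely range from 15000 nM to 100000 nM, and a real chance that the assay again returns only a limit.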

Compound 3, half-maximal inhibitory concentration: 33600 nM
Estimate against measurement, compound 3: 1.2-fold (0.08 log units) above; low and high end bracket the measured number.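

Among the compounds shown here, compound 3 gives the first step at this position in this assay with a number at both ends, a 1.3-fold lower number from compound 2 to compound 3 (0.11 log units; within the scatter), so the change now has a size and not just a floor. Trifluoromethyl in place of methoxy, para to a large group, swaps a smaller group carrying a hydrogen-bond acceptor for a larger one without, and the printed step stays within the scatter. The other new step, an at least 1.4-fold lower number from compound 1 to compound 3 (0.17 log units; that floor lies within the scatter), also stays within the scatter at its floor, and it remains only a floor because compound 1 is reported as a limit and not as a number: the limit of > 50000 nM in this assay, at which 1 of the 3 values shown sits.

The compounds shown leave open whether any group at this position can move the number beyond the scatter, as methoxycarbonyl, methoxy and trifluoromethyl are the only groups seen there, and an amine, a carboxylic acid or a longer chain could behave differently. As far as these compounds go, the rest of the core is the same in all three compounds, so what a change elsewhere in the structure would do, and whether this position matters more in another setting, stays unknown.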